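Swapping Hydroxy for Chloro: What the Cytotoxicity Data Allow

The source may report more compounds than this note shows. Statements on the series, on what has been measured and on what is new or still open speak of the compounds shown alone.

Compound 1 `CCOC(=O)c1c(-c2cccc(Cl)c2)[nH]c2cc(OC)ccc2c1=O` gives > 21500 nM in an ADME assay on BJ cells (Homo sapiens) for cytotoxicity, read by luminescence, with a stated time of 72 h (on this read-out higher numbers stand for an effect only at larger amounts of compound and lower numbers for an effect already at smaller amounts), which is a limit of the assay.
Compound 2 `CCOC(=O)c1c(-c2cccc(O)c2)[nH]c2cc(OC)ccc2c1=O` gives > 21500 nM in this assay, also a limit.
Compound 3 `CCOC(=O)c1c(-c2cccc(-c3ccccc3)c2)[nH]c2cc(O)ccc2c1=O` gives > 21500 nM in this assay, again a limit.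

Compound 2 and compound 1 differ by chloro in place of hydroxy on an aromatic carbon. The step that the two limits leave unreadable from compound 2 to compound 1 cannot be read because both values sit at the limit of > 21500 nM in this assay, at which 3 of the 3 values shown sit. Compound 4 `CCOC(=O)c1c(-c2cccc(-c3ccccc3)c2)[nH]c2cc(Cl)ccc2c1=O` is not yet measured; it differs from compound 3 by chloro in place of hydroxy on an aromatic carbon. This is the same kind of change as from compound 2 to compound 1, but the place differs: in the earlier pair it sits on a six-membered aromatic ring of carbon only, meta to a large group, whereas here the ring is part of a fused or bridged system of two rings, meta to a fused ring and para to a fused ring. The difference between the core of compound 3 and the core of compound 2 is not broken down here.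

The step from compound 3 to compound 4 is expected to be a number no higher from compound 3 to compound 4 (the limit leaves the size open), since compound 3 gives only > 21500 nM and the earlier pair never left (the limit of > 21500 nM in this assay, at which 3 of the 3 values shown sit). Compound 4 is therefore expected to give 21500 nM, most probably again reported only as a limit.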

Compound 4, half-maximal effective concentration: > 21500 nM
Compound 4: no number, only a limit (the forecaster's own chance of this, stated with the estimate: 80%); the middle value sits exactly at the limit.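

No step can be read between compound 3 and compound 4, because both values are limits rather than numbers: the limit of > 21500 nM in this assay, at which 4 of the 4 values shown sit.

The compounds shown leave open whether chloro in place of hydroxy changes the amount of compound needed for an effect in this assay, as none of them gives a number.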